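Notes on the series: bromo following fluoro

The source may hold more compounds than are shown below. What is called first, only, known or untested is meant among the compounds shown, and "the series" means these compounds.

The shared core is that of compound 1 `CC(=O)Nc1ccc(S(=O)(=O)NNc2ccccc2)cc1`, which in an assay for inhibition of Indoleamine 2,3-dioxygenase 1 (Homo sapiens), read by spectrophotometry, with stated times of 1 h and 4 h (on this read-out lower numbers stand for stronger inhibition and higher numbers for weaker inhibition), gives 71 nM. Compound 2 `CC(=O)Nc1ccc(S(=O)(=O)NNc2ccc(C#N)cc2)cc1` gives 5670 nM in this assay, and compound 3 `CC(=O)Nc1ccc(S(=O)(=O)NNc2ccc(F)cc2)cc1` gives 79 nM. Of the three numbers, compound 3 holds the second highest; its nearest neighbour is compound 1, which stands within the scatter of it, while compound 2 lies far above it. Among the measured steps there is a 1.1-fold higher number from compound 1 to compound 3 (0.05 log units; within the scatter), whereas there is an 80-fold higher number from compound 1 to compound 2 (1.90 log units; beyond the scatter) and a 72-fold lower number from compound 2 to compound 3 (1.86 log units; beyond the scatter).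

Compound 4 `CC(=O)Nc1ccc(S(=O)(=O)NNc2ccc(F)c(Br)c2)cc1` differs from compound 3 by bromo in place of hydrogen on an aromatic carbon. Among the compounds with values here, no measured step adds a bromo group, so the bearing of the known steps is indirect: the only halogen change, the fluoro step, stayed within the scatter, and the one large change involved a cyano group rather than a halogen. For compound 4 in this assay the expected step is therefore small, a 1.4-fold higher number from compound 3 to compound 4 (0.14 log units; within the scatter), and may not exceed the scatter. Compound 4 is estimated at 110 nM, with an expected range from 35 nM to 350 nM.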

Compound 4, half-maximal inhibitory concentration: 128 nM
Beside the measured number, compound 4's estimate is 1.2-fold (0.07 log units) below it, within the range that was stated.
By their numbers in this assay, from the lowest: compounds 1, 3 and 4 (each within the scatter of the next); then compound 2.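

In this assay there is a 1.6-fold higher number from compound 3 to compound 4 (0.21 log units; within the scatter), so a bromo group can stand in place of hydrogen at this aromatic carbon, ortho to a fluoro group and meta to a large group, with a step that stays within the scatter. The earlier steps changed only the group at the site that carries fluoro in compound 3, whereas compound 4 is the only compound shown with a substituent at this second site and the only one with two substituents on this ring, and the fluoro group remains in place there. The data give the size of this step but no measurement that accounts for it.

The compounds shown leave open whether the bromo group would give a similar result without the neighbouring fluoro group, since the only bromo step starts from compound 3. Within the data shown here, they also leave open whether this position would accept a nitrile, the group in the one large step, or an amine, a carboxylic acid or a longer chain.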